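Swapping a phenethyl for 3-fluorophenyl on a lactone inhibitor

The source may hold more compounds than are shown below. What is called first, only, known or untested is meant among the compounds shown, and "the series" means these compounds.

Of the compounds shown here, three have so far been tested in an assay for inhibition of 3-hydroxy-3-methylglutaryl-coenzyme A reductase (Rattus norvegicus); a lower number here means a stronger inhibitor, a higher number a weaker inhibitor. Compound 1, `O=C1C[C@H](O)C[C@@H](/C=C/c2c(Cl)cc(Cl)cc2CCc2ccccc2)O1`, gives 430 nM, the highest of the three numbers. Compound 2, `CO[C@H]1CC(=O)O[C@H](/C=C/c2c(C)cc(C)cc2-c2ccc(F)c(C)c2)C1`, gives 106 nM, and compound 3, `O=C1C[C@H](O)CC(CCc2c(Cl)cc(Cl)cc2-c2ccccc2)O1`, gives 100 nM; both of these lie well below the number for compound 1, by more than the usual scatter.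

The next compound to be measured is compound 4, `O=C1C[C@H](O)C[C@@H](/C=C/c2c(Cl)cc(Cl)cc2-c2cccc(F)c2)O1`. It differs from compound 1 in a single place: 3-fluorophenyl in place of phenethyl on an aromatic carbon. The two-carbon chain that held the aromatic ring away from the core is gone, and a fluorine-bearing aromatic ring now sits on the aromatic carbon directly.

Among the measured compounds shown here, no measured pair shows exactly this change, so the expected step rests on the general picture. Compound 4 is expected to give a lower number than compound 1, because compound 3 gives 100 nM and compound 2 gives 106 nM, both far below compound 1. The estimated step from one to the other is a 3.6-fold lower number from compound 1 to compound 4 (0.55 log units; beyond the scatter), beyond the scatter. Compound 4 is therefore expected to reach about 120 nM, within a range from 40 nM to 350 nM.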

Compound 4, half-maximal inhibitory concentration: 70 nM
Compound 4: middle estimate off by 1.7-fold (0.23 log units), on the high side; the measured number falls inside the stated range.
By their numbers in this assay, from the lowest: compounds 4, 3 and 2 (each within the scatter of the next); then compound 1.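

Placing 3-fluorophenyl in place of phenethyl on this aromatic carbon in this assay gives a 6.1-fold lower number from compound 1 to compound 4 (0.79 log units; beyond the scatter) and provides the first direct comparison at this position. It shows that phenethyl is not needed here for inhibition: an aromatic ring attached directly to this carbon, ortho to a large group, gives the lower number in this pair. No measurement shown explains the difference.

This single change both removes the chain and adds a fluorine, and the two compounds cannot separate those contributions. A plain phenyl group on the same core would test the fluorine on its own, while a benzyl group or a longer chain ending in 3-fluorophenyl would show how the number responds to the distance between the two rings.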